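From 3-Bromophenyl to 4-Bromophenyl

The source may report more compounds than this note shows. Statements on the series, on what has been measured and on what is new or still open speak of the compounds shown alone.

Of the compounds shown here, three with a shared core have been measured in a functional assay on HCT-116 cells (Homo sapiens) for antiproliferative activity, read by MTT assay, with a stated time of 72 h; on this read-out higher numbers stand for weaker inhibition and lower numbers for stronger inhibition. Compound 1 `COc1ccc(OCCCON2C(N)=NC(N)=NC23CCOCC3)cc1` gives 1500 nM, compound 2 `NC1=NC2(CCOCC2)N(OCCCOc2ccc(Cl)cc2Cl)C(N)=N1` gives 880 nM, and compound 3 `NC1=NC2(CCOCC2)N(OCCCOc2cccc(Br)c2)C(N)=N1` gives 40 nM, the lowest number of the three. The next candidate is compound 4 `NC1=NC2(CCOCC2)N(OCCCOc2ccc(Br)cc2)C(N)=N1`, with this change: 4-bromophenyl in place of 3-bromophenyl on an oxygen on a saturated carbon. In words, 4-bromophenyl stands in place of 3-bromophenyl on an oxygen on a saturated carbon.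

Going by the values given here, no measured step makes this exact swap, so the evidence is indirect. The a 38-fold lower number from compound 1 to compound 3 (1.57 log units; beyond the scatter) and a 22-fold lower number from compound 2 to compound 3 (1.34 log units; beyond the scatter) were both large, and both ended on the 3-bromophenyl group. The a 1.7-fold lower number from compound 1 to compound 2 (0.23 log units; within the scatter) stayed within the scatter. Among the compounds with values here, only compound 3 has reached a low number so far, and compound 4 gives up its 3-bromophenyl group, so a move towards a higher number, meaning weaker inhibition, seems likely, though smaller than those two large steps. The expected change is a 5.0-fold higher number from compound 3 to compound 4 (0.70 log units; beyond the scatter). For compound 4 the estimated value is 200 nM, with an expected range of 40 nM to 900 nM.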

Compound 4, half-maximal inhibitory concentration: 320 nM
The estimate for compound 4 lay 1.6-fold (0.20 log units) below the measured number, and the stated range covers the measured number.
By their numbers in this assay, from the lowest: compound 3; then compound 4; then compounds 2 and 1 (each within the scatter of the next).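

Moving the bromine alone, with the same atoms joined differently, gives an 8.0-fold higher number from compound 3 to compound 4 (0.90 log units; beyond the scatter) and shows that on this ring where the bromo sits matters, not only that it is present. The 4-bromophenyl group still holds part of the gain, with a 2.8-fold lower number from compound 2 to compound 4 (0.44 log units; beyond the scatter) and, for bromo in place of methoxy on an aromatic carbon, a 4.7-fold lower number from compound 1 to compound 4 (0.67 log units; beyond the scatter) as well. Nothing measured here explains why the two bromophenyl groups differ.

The compounds shown leave open whether the advantage of the 3-bromophenyl group is special to bromo or would also appear with another group, such as a nitrile or a carboxylic acid, in its place. They also leave open how a longer chain between the ring and the shared core would change the picture.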